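Swapping the hydroxyphenyl ester for a pyridyl ester

The source may hold more compounds than are shown below. What is called first, only, known or untested is meant among the compounds shown, and "the series" means these compounds.

Compound 1 `CC(=O)Oc1ccccc1C(=O)O[C@H]1CO[C@H]2[C@@H]1OC[C@H]2OC(=O)c1cccc(O)c1` stands lowest of three in an ADME assay on a cell-free system (plasma, Homo sapiens) for metabolic stability, with Plasma (Rattus norvegicus) as the target, read by HPLC, at pH 7.4 (a lower number here means that the compound disappears faster, a higher number that the compound lasts longer), where compound 1 gives 0.0183 h. Compound 2 `CCC(=O)O[C@@H]1CO[C@H]2[C@@H]1OC[C@@H]2OC(=O)c1ccccc1OC(C)=O` gives 0.0608 h in this assay, and compound 3 `COc1ccc(C(=O)O[C@@H]2CO[C@H]3[C@@H]2OC[C@@H]3OC(=O)c2ccccc2OC(C)=O)cc1` gives 0.0525 h. Both replacements of the 3-hydroxyphenyl on the carbonyl carbon raised the half-life modestly: a 3.3-fold higher number from compound 1 to compound 2 (0.52 log units; beyond the scatter) and a 2.9-fold higher number from compound 1 to compound 3 (0.46 log units; beyond the scatter). Compound 4 `CC(=O)Oc1ccccc1C(=O)O[C@H]1CO[C@H]2[C@@H]1OC[C@H]2OC(=O)c1cccnc1` alters compound 1 at the same place: pyridin-3-yl in place of 3-hydroxyphenyl on a carbonyl carbon. Because a 3.3-fold higher number from compound 1 to compound 2 (0.52 log units; beyond the scatter) and a 2.9-fold higher number from compound 1 to compound 3 (0.46 log units; beyond the scatter) both point upward and beyond the scatter, a modest rise in this assay is expected for compound 4 as well, roughly a 2.5-fold higher number from compound 1 to compound 4 (0.39 log units; beyond the scatter). Compound 4 is therefore estimated at 0.045 h in this assay, with a likely range from 0.02 h to 0.1 h.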

Compound 4, half-life: 0.0232 h
The estimate for compound 4 lay 1.9-fold (0.29 log units) above the measured number; low and high end bracket the measured number.
By their numbers in this assay, from the lowest: compounds 1 and 4 (each within the scatter of the next); then compounds 3 and 2 (each within the scatter of the next).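

In this assay, not every replacement of 3-hydroxyphenyl on this carbonyl carbon shifts the half-life: pyridin-3-yl shows only (a 1.3-fold higher number from compound 1 to compound 4 (0.10 log units; within the scatter)). The same group falls clearly short of the other two replacements, with (a 2.3-fold lower number from compound 3 to compound 4 (0.35 log units; beyond the scatter)) and (a 2.6-fold lower number from compound 2 to compound 4 (0.42 log units; beyond the scatter)), so the outcome at this position depends on which group enters. Nothing available explains this difference. The compounds shown leave open how pyridin-2-yl or pyridin-4-yl would behave here. They also leave open what an amine, a carboxylic acid or a chain longer than ethyl would do at this carbonyl carbon.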